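The source may report more compounds than this note shows. Statements on the series, on what has been measured and on what is new or still open speak of the compounds shown alone.

In a functional assay on PANC-1 cells (Homo sapiens) for cytotoxicity, read by WST assay, with a stated time of 24 h (a lower number here means a stronger inhibitor, a higher number a weaker inhibitor), the measured compounds stand as follows:
- compound 1 `Cc1ccc(CCCCCCCCC(=O)N2CCCCC2)cc1` gives > 100000 nM as a limit
- compound 2 `O=C(CCCCCCCCc1ccc(C(F)(F)F)cc1)N1CCCCC1` gives 54000 nM as a number
- compound 3 `N#Cc1ccc(CCCCCCCCC(=O)N2CCCCC2)cc1` gives > 100000 nM as a limit

Compound 3 stands at the limit of > 100000 nM in this assay, at which 2 of the 3 values shown sit, and has no number of its own. The change to compound 4 `O=C(CCCCCCCCc1cccc(F)c1)N1CCCCC1` is 3-fluorophenyl in place of 4-cyanophenyl on a saturated chain carbon, eight bonds along the chain from a carbonyl carbon and puts 3-fluorophenyl in place of 4-cyanophenyl on a saturated chain carbon, eight bonds along the chain from a carbonyl carbon. Going by the values given here, no measured compound carries 3-fluorophenyl, so the evidence is indirect. Among the compounds with values here, the steps that bear on it are an at least 1.8-fold lower number from compound 1 to compound 2 (0.26 log units; that floor lies within the scatter) and an at least 1.8-fold higher number from compound 2 to compound 3 (0.26 log units; that floor lies within the scatter) while a step that the two limits leave unreadable from compound 1 to compound 3 adds no size. Within the data shown here, a large step is therefore not expected, and any movement is expected towards a lower number, with compound 2 at 54000 nM as the only numerical guide. The expected step is an at least 1.2-fold lower number from compound 3 to compound 4 (0.09 log units; that floor lies within the scatter) and may not exceed the scatter. The estimate for compound 4 is 80000 nM on current evidence. The expected range for compound 4 runs from 40000 nM to 150000 nM and a report as a limit would not be surprising.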

Compound 4, half-maximal inhibitory concentration: > 100000 nM
Compound 4 ended at the assay's limit; the forecaster's own chance of this, stated with the estimate: 50%; middle value at least 1.2-fold (0.09 log units) away from the limit.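

In this assay compound 4 gives > 100000 nM, a limit and not a number. The steps to compound 4 from compound 1 and compound 3 therefore cannot be read: the limit of > 100000 nM in this assay, at which 3 of the 4 values shown sit.

The compounds shown leave open how far 3-fluorophenyl, 4-cyanophenyl and 4-methylphenyl differ in this assay.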